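Methoxy to hydroxy on the aryl urea series

The source may report more compounds than this note shows. Statements on the series, on what has been measured and on what is new or still open speak of the compounds shown alone.

Two compounds of the shared core have numbers in a functional assay on NCI/ADR-RES cells (Homo sapiens) for inhibition, read by sulforhodamine B assay, with a stated time of 48 h; on this read-out lower numbers stand for stronger inhibition of growth and higher numbers for weaker inhibition of growth. Compound 1 `O=C(Nc1cccc(-n2cc(-c3ccncc3)c(-c3ccc(Cl)c(O)c3)n2)c1)Nc1cccc(C(F)(F)F)c1` gives 2140 nM in this assay, and compound 2 `COc1cc(-c2nn(-c3cccc(NC(=O)Nc4ccc(Cl)c(Cl)c4)c3)cc2-c2ccncc2)ccc1Cl` gives 990 nM. Compound 2 thus stands on the lower of the two numbers, with compound 1 beyond the usual scatter from it; the two differ in more than one place, so no single step can be read from them.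

Compound 3 `O=C(Nc1cccc(-n2cc(-c3ccncc3)c(-c3ccc(Cl)c(O)c3)n2)c1)Nc1ccc(Cl)c(Cl)c1` is the next member. It differs from compound 2 in one place only: hydrogen in place of methyl on an oxygen on an aromatic ring. Within the data shown here, no measured pair isolates this change, so nothing in the data fixes its direction. The expected step from compound 2 to compound 3 in this assay is a 1.3-fold higher number from compound 2 to compound 3 (0.12 log units; within the scatter), small and not beyond the scatter. Compound 3 is accordingly expected to give about 1300 nM in this assay, within a range of 500 nM to 3500 nM.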

Compound 3, concentration for 50% growth inhibition: 2740 nM
Estimate against measurement, compound 3: 2.1-fold (0.32 log units) below, and the stated range covers the measured number.
By their numbers in this assay, from the lowest: compound 2; then compounds 1 and 3 (each within the scatter of the next).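

In this assay, among these compounds, methoxy to hydroxy on the 4-chloro-3-methoxyphenyl group gives a 2.8-fold higher number from compound 2 to compound 3 (0.44 log units; beyond the scatter), the first isolated reading at this position, and it shows that the methyl on this oxygen can be lost only with a step beyond the scatter. With the hydroxy held constant, 3,4-dichlorophenyl in place of 3-(trifluoromethyl)phenyl on an amide-type nitrogen gives a 1.3-fold higher number from compound 1 to compound 3 (0.11 log units; within the scatter), so this swap does not separate compound 1 and compound 3 in this read-out. Nothing at hand gives a reason for the step at the oxygen.

On these data alone, it remains open whether the methoxy to hydroxy step holds with 3-(trifluoromethyl)phenyl on the amide-type nitrogen. Also open, as far as these compounds go, is how an ethoxy group or an amine would read in place of the methoxy.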